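The compounds below may be only part of what the source reports. "The series", "measured", "known", "first", "only" and "open" are said of these compounds alone.

Measured compounds:
compound 1 `O=C(Nc1ccc(S(=O)(=O)Nc2ccccc2Cl)cc1)c1ccc(Cl)cc1Cl` – 1260 nM
compound 2 `Cc1ccccc1NS(=O)(=O)c1ccc(NC(=O)c2ccc(Cl)cc2Cl)cc1` – 1230 nM
compound 3 `COc1ccc(NS(=O)(=O)c2ccc(NC(=O)c3ccc(Cl)cc3Cl)cc2)cc1` – > 100000 nM

In a functional assay on HEK293 cells for agonist activity at probable G-protein coupled receptor 27 (Homo sapiens), read by a luciferase reporter and beta-arrestin recruitment, with a stated time of 10 min (a higher number here means that more compound is needed for the effect, a lower number that less compound is needed), compound 1 gives 1260 nM and compound 2 gives 1230 nM; the step of a 1.0-fold lower number from compound 1 to compound 2 (0.01 log units; within the scatter) shows that methyl in place of chloro on an aromatic carbon changes little. Compound 3 stands apart: in this assay compound 3 gives only a limit of > 100000 nM, not a number. The two steps into it, an at least 79-fold higher number from compound 1 to compound 3 (1.89 log units; beyond the scatter) and an at least 81-fold higher number from compound 2 to compound 3 (1.91 log units; beyond the scatter), were both large rises, each bringing a 4-methoxyphenyl onto the sulfonamide nitrogen (the limit of > 100000 nM in this assay, at which 1 of the 3 values shown sits).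

Compound 4 `O=C(Nc1ccc(S(=O)(=O)NCc2ccccc2)cc1)c1ccc(Cl)cc1Cl` differs from compound 3 in one place: benzyl in place of 4-methoxyphenyl on a sulfonamide nitrogen. Within the data shown here, no measured step swaps an aromatic ring for a benzyl on this nitrogen, so the measured steps give only a rough guide: they show that the 4-methoxyphenyl of compound 3 sits at the limit, while the groups of compound 1 and compound 2 do not. Because compound 3 sits at the limit > 100000 nM, the step of an at least 6.6-fold lower number from compound 3 to compound 4 (0.82 log units; beyond the scatter) is expected to be a fall, but the size is uncertain. Compound 4 is therefore estimated at 15000 nM, in the range 1500 nM to 100000 nM.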

Compound 4, half-maximal effective concentration: > 100000 nM
Compound 4: only a limit was reported (the forecaster's own chance of this, stated with the estimate: 35%); middle value at least 6.6-fold (0.82 log units) from the limit.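

On the sulfonamide nitrogen, the loss of a measurable response is not confined to 4-methoxyphenyl: benzyl also gives a large rise, with an at least 81-fold higher number from compound 2 to compound 4 (1.91 log units; beyond the scatter) and an at least 79-fold higher number from compound 1 to compound 4 (1.89 log units; beyond the scatter). Among the four compounds, only the 2-chlorophenyl of compound 1 and the 2-methylphenyl of compound 2 give an actual number, while compound 4 joins compound 3 at the assay's limit: the limit of > 100000 nM in this assay, at which 2 of the 4 values shown sit. Compound 3 and compound 4 both give only limits, so the step from one to the other cannot be read and the two groups cannot be ranked.

Going by these compounds, it remains open whether a plain phenyl, a 2-methoxyphenyl or a 4-chlorophenyl on this nitrogen would give a number. On these data alone, the behaviour of a simple n-butyl chain or a chain carrying an amine at this position also remains unknown.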